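Removing a chloro group on a related urea pair

The source may hold more compounds than are shown below. What is called first, only, known or untested is meant among the compounds shown, and "the series" means these compounds.

Measured compounds:
Compound 1, `Cc1ccc(NC(=O)Nc2nnc(Sc3ncnc4scc(-c5ccncc5)c34)s2)cc1Cl`: 4700 nM
Compound 2, `Cc1ccc(NC(=O)Nc2nnc(Sc3ncnc4scc(-c5ccncc5)c34)s2)cc1`: 2100 nM
Compound 3, `O=C(Nc1ccc(Cl)c(Cl)c1)Nc1nnc(Sc2ncnc3scc(-c4ccncc4)c23)s1`: 3600 nM

These three compounds were tested in a functional assay on PC-3 cells (Homo sapiens) for antiproliferative activity, read by MTT assay, with a stated time of 48 h; on this read-out higher numbers stand for weaker inhibition and lower numbers for stronger inhibition. Compound 1 gives 4700 nM in this assay, compound 2 gives 2100 nM, and compound 3 gives 3600 nM. Among the measured compounds shown here, the only change from compound 1 to compound 2 is hydrogen in place of chloro on an aromatic carbon and it made the step of a 2.2-fold lower number from compound 1 to compound 2 (0.35 log units; beyond the scatter). Compound 1 and compound 3 differ by chloro in place of methyl on an aromatic carbon, a step of a 1.3-fold lower number from compound 1 to compound 3 (0.12 log units; within the scatter). Compound 2 and compound 3 differ in the step of a 1.7-fold higher number from compound 2 to compound 3 (0.23 log units; within the scatter).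

Compound 4, `O=C(Nc1ccc(Cl)cc1)Nc1nnc(Sc2ncnc3scc(-c4ccncc4)c23)s1`, has not been measured in this assay. It differs from compound 3 by hydrogen in place of chloro on an aromatic carbon. This is the same kind of change as from compound 1 to compound 2, but not the same: in compound 1 the leaving chloro sits ortho to a methyl group, while in compound 3 it sits ortho to a chloro group. For the measured compounds named here, with only one earlier example of this change, the expectation for compound 4 rests on the step of a 2.2-fold lower number from compound 1 to compound 2 (0.35 log units; beyond the scatter) applied to compound 3 at 3600 nM. On that basis the step from compound 3 to compound 4 is expected to be about a 2.0-fold lower number from compound 3 to compound 4 (0.30 log units; within the scatter), and compound 4 is estimated to give 1800 nM in this assay, most likely between 800 nM and 3800 nM.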

Compound 4, half-maximal inhibitory concentration: 7700 nM
Beside the measured number, compound 4's estimate is 4.3-fold (0.63 log units) below it; the whole stated range lies below it.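

Taking one chloro group off the aromatic ring did not carry over from one core to the other in this assay: with a chloro group left behind rather than a methyl group, the result was a 2.1-fold higher number from compound 3 to compound 4 (0.33 log units; beyond the scatter), opposite in direction to the earlier step: the same change on two cores in this assay, a 2.2-fold lower number (0.35 log units; beyond the scatter) from compound 1 to compound 2 and a 2.1-fold higher number (0.33 log units; beyond the scatter) from compound 3 to compound 4, 4.8-fold (0.68 log units) apart, beyond the scatter of two such steps

Putting chloro in place of methyl also depended on its surroundings, with a 3.7-fold higher number from compound 2 to compound 4 (0.56 log units; beyond the scatter) when no second chloro group was on the ring, set against a much smaller earlier step: the same change on two cores in this assay, a 1.3-fold lower number (0.12 log units; within the scatter) from compound 1 to compound 3 and a 3.7-fold higher number (0.56 log units; beyond the scatter) from compound 2 to compound 4, 4.8-fold (0.68 log units) apart, beyond the scatter of two such steps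

These two comparisons show that, in this series, neither change has one fixed effect, so a step seen on one compound is a poor guide to the next, but they do not show why, and the remaining step, a 1.6-fold higher number from compound 1 to compound 4 (0.21 log units; within the scatter), does not settle this.

The compounds shown leave open what happens when the remaining chloro or methyl group is replaced by another group, such as a fluoro, a methoxy or an amine. They also leave open whether a ring with no such group at all would follow compound 2 or compound 4, and whether either pattern would hold in other cells.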